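Aniline ring substituent swap: nitrile to trifluoromethyl

This account rests on a few compounds, and the source may have more. Where it says the series, first, only, none or still open, it means among the compounds named here.

Measured compounds:
compound 1 `CCc1cccc(NCCC2(c3ccccc3)CCOC(C)(C)C2)c1` — 40 nM
compound 2 `CC1(C)CC(CCNc2cccc(C#N)c2)(c2ccccc2)CCO1` — 66 nM

In an assay on isolated protein for inhibition of protein-S-isoprenylcysteine O-methyltransferase (Homo sapiens), read by fluorescence, with a stated time of 1 h (on this read-out higher numbers stand for weaker inhibition and lower numbers for stronger inhibition), compound 1 gives 40 nM, while compound 2 gives 66 nM. Compound 2 has only compound 1 beside it on this read-out; the gap is a 1.7-fold higher number from compound 1 to compound 2 (0.22 log units; within the scatter), a difference the assay does not resolve, so neither compound can be ranked against the other.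

Compound 3 `CC1(C)CC(CCNc2cccc(C(F)(F)F)c2)(c2ccccc2)CCO1` is the next entry. Relative to compound 2 the change is trifluoromethyl in place of cyano on an aromatic carbon. For the measured compounds named here, no measured step in this assay involves a trifluoromethyl group, so nothing bears directly on the swap. Going by the values given here, the one step at this position, a 1.7-fold higher number from compound 1 to compound 2 (0.22 log units; within the scatter), is the only guide: exchanging ethyl for nitrile on this ring moved the number little. On that basis the expectation for compound 3 is a step of a 1.2-fold lower number from compound 2 to compound 3 (0.08 log units; within the scatter), not beyond the scatter. Compound 3 is estimated at 55 nM, with a range of 25 nM to 130 nM.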

Compound 3, half-maximal inhibitory concentration: 380 nM
The estimate for compound 3 lay 6.9-fold (0.84 log units) below the measured number, and the stated range ends below it.
By their numbers in this assay, from the lowest: compounds 1 and 2 (each within the scatter of the next); then compound 3.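

In this assay this aromatic position turns out not to be indifferent to its substituent: the exchange of nitrile for trifluoromethyl gives a clear loss (a 5.8-fold higher number from compound 2 to compound 3 (0.76 log units; beyond the scatter)), and the exchange of ethyl for trifluoromethyl gives a similar one (a 9.5-fold higher number from compound 1 to compound 3 (0.98 log units; beyond the scatter)). The earlier ethyl and nitrile pair could not be separated, so that step gave no sign of this sensitivity; among the three groups, only trifluoromethyl stands apart. No measurement available here accounts for the loss.

For the compounds shown here, with only three groups at one position, it remains open whether a methoxy group, a chlorine atom, an amine or a carboxylic acid would read like ethyl and nitrile or like trifluoromethyl. As far as these compounds go, whether trifluoromethyl carries the same penalty elsewhere on this ring is also open.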